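This account rests on a few compounds, and the source may have more. Where it says the series, first, only, none or still open, it means among the compounds named here.

Measured in a functional assay on HT-29 cells (Homo sapiens); on this read-out higher numbers stand for an effect only at larger amounts of compound and lower numbers for an effect already at smaller amounts:
- compound 1 `CNC(=O)c1ccc(-c2cc(C(=O)N[C@H]3CCCNC3)c(NC(N)=O)s2)cc1`: 4300 nM
- compound 2 `NC(=O)Nc1sc(-c2ccc(C(=O)N3CCCCC3)cc2)cc1C(=O)N[C@H]1CCCNC1`: 130 nM
- compound 3 `NC(=O)Nc1sc(-c2ccc(C(=O)N3CCOCC3)cc2)cc1C(=O)N[C@H]1CCCNC1`: 610 nM

Compound 3 holds the second highest of the three numbers, above compound 2 and below compound 1. Compound 4 `CN(C)C(=O)c1ccc(-c2cc(C(=O)N[C@H]3CCCNC3)c(NC(N)=O)s2)cc1` carries dimethylamino in place of morpholin-4-yl on a carbonyl carbon. Three measured steps at this carbonyl bear on the change: a 4.7-fold higher number from compound 2 to compound 3 (0.67 log units; beyond the scatter) and a 7.0-fold lower number from compound 1 to compound 3 (0.85 log units; beyond the scatter), both modest, and a 33-fold lower number from compound 1 to compound 2 (1.52 log units; beyond the scatter), large. Dimethylamino has no ring, like methylamino in compound 1, but none of the three is a direct precedent, so a number within that span is expected. In this assay, on these data alone, no step beyond the scatter is expected, and the direction stays open. The expected step is a 1.0-fold lower number from compound 3 to compound 4 (0.01 log units; within the scatter). For compound 4 the estimate is 600 nM, with an expected range of 200 nM to 1800 nM.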

Compound 4, half-maximal effective concentration: 320 nM
The estimate for compound 4 lay 1.9-fold (0.27 log units) above the measured number; the range from low to high includes it.
By their numbers in this assay, from the lowest: compound 2; then compounds 4 and 3 (each within the scatter of the next); then compound 1.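

In this assay dimethylamino, which has no ring, stays level with morpholin-4-yl (a 1.9-fold lower number from compound 3 to compound 4 (0.28 log units; within the scatter)), so at this carbonyl the absence of a ring does not by itself separate the two. Piperidin-1-yl remains apart from dimethylamino (a 2.5-fold higher number from compound 2 to compound 4 (0.39 log units; beyond the scatter)), and adding one methyl to the amide-type nitrogen of compound 1 already gives a large step (a 13-fold lower number from compound 1 to compound 4 (1.13 log units; beyond the scatter)). No available evidence explains these steps.

Still open, on these data alone, is how pyrrolidin-1-yl, azetidin-1-yl or the longer-chain diethylamino would read on this carbonyl carbon.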